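The source may hold more compounds than are shown below. What is called first, only, known or untested is meant among the compounds shown, and "the series" means these compounds.

Measured compounds:
compound 1 `Cc1cc(C)cc(OCCCON2C(N)=NC(N)=NC23CCOCC3)c1`, 84.3%
compound 2 `NC1=NC2(CCOCC2)N(OCCCOc2ccc(Cl)c(Cl)c2)C(N)=N1`, > 90%

In an assay on isolated protein for inhibition of Dihydrofolate reductase (Homo sapiens), read by spectrophotometry, using NADPH, with stated times of 5 s and 6 min, tested at 5 uM (a lower number here means a weaker effect, a higher number a stronger effect of the compound at the concentration tested), compound 1 gives 84.3%. For compound 2 the value > 90% is a limit of the assay rather than a number. Compound 2 therefore stands only at a limit, the one described by the limit of > 90% in this assay, at which 1 of the 2 values shown sits, and no exact number for it is known. Going by the values given here, the single measured step, a number at least 5.7 percentage points higher from compound 1 to compound 2 (that floor lies within the scatter), follows the exchange of the 3,5-dimethylphenyl for the 3,4-dichlorophenyl group; its floor lies within the usual scatter, so this step shows no change beyond that scatter.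

Compound 3 `NC1=NC2(CCOCC2)N(OCCCOc2cccc(Cl)c2)C(N)=N1` differs from compound 2 by hydrogen in place of chloro on an aromatic carbon, which, taken one bond further out, reads 3,4-dichlorophenyl to 3-chlorophenyl. The step from compound 1 to compound 2 is the only one that bears on it, and it was small. A change of similar size is therefore expected, that is, none beyond the scatter, though with some room for a lower number because compound 2 sits at a limit. Compound 3 is expected to give 85%, between 70% and 95%, a step of a number at least 5 percentage points lower from compound 2 to compound 3 (that floor lies within the scatter).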

Compound 3, a percentage reported as inhibition, at one concentration (the size of the read-out at that concentration, not a potency): 83.2%
Compound 3: the middle estimate sits 1.8 percentage points above what was measured; measured number inside the range.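

In this assay, the change from 3,4-dichlorophenyl to 3-chlorophenyl removes the chloro group para to a large group and gives a number at least 6.8 percentage points lower from compound 2 to compound 3 (that floor lies within the scatter), so this aromatic carbon is now tested directly, though no change beyond the scatter is shown. From the compounds shown here alone, the true size of that step stays unknown because compound 2 stands at a limit and has no exact number: the limit of > 90% in this assay, at which 1 of the 3 values shown sits. The exchange of 3,5-dimethylphenyl for 3-chlorophenyl gives a number 1.1 percentage points lower from compound 1 to compound 3 (within the scatter), so these two groups cannot be told apart in this assay at the single concentration tested.

What the compounds shown leave open is whether the 3,4-dichlorophenyl group truly differs from the other two aryl groups, a question that a read-out at one concentration cannot settle while compound 2 stands at a limit. Also open, going by these compounds, is whether a methoxy group, an amine or a carboxylic acid on this same aromatic carbon, or a longer chain between the aryl ether and the core, would move the read-out beyond the scatter.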